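The source may hold more compounds than are shown below. What is called first, only, known or untested is meant among the compounds shown, and "the series" means these compounds.

Three compounds have been measured in a functional assay on MCF7 cells (Homo sapiens) for inhibition, read by sulforhodamine B assay; a lower number here means a stronger inhibitor, a higher number a weaker inhibitor:

Compound 1 `O=C1C(Nc2ccccc2F)=CC(=O)c2c1nc1n2[C@H]2OC[C@@H](O)[C@H]2OC1`: > 4000 nM, a limit of the assay rather than a number.
Compound 2 `O=C1C=C(Nc2cccc(F)c2)C(=O)c2c1nc1n2[C@H]2OC[C@@H](O)[C@H]2OC1`: 5500 nM
Compound 3 `CCOc1ccc(NC2=CC(=O)c3nc4n(c3C2=O)[C@H]2OC[C@@H](O)[C@H]2OC4)cc1`: 1430 nM

Compound 1 therefore stands at the weak end of what is shown, as the limit of > 4000 nM in this assay, at which 1 of the 3 values shown sits, records. Compound 4 `CCCc1ccc(NC2=CC(=O)c3c(nc4n3[C@H]3OC[C@@H](O)[C@H]3OC4)C2=O)cc1` differs from it by 4-propylphenyl in place of 2-fluorophenyl on an amine nitrogen. Among the compounds with values here, the one measured step that resembles this change is a 3.8-fold lower number from compound 2 to compound 3 (0.59 log units; beyond the scatter), where a fluorophenyl likewise gave way to a larger 4-ethoxyphenyl on the same amine nitrogen, and the number fell by a modest amount beyond the scatter. A similar modest fall is expected here, so the estimate for compound 4 is 1500 nM, within 500 nM to 5000 nM. This expected gain corresponds to an at least 2.6-fold lower number from compound 1 to compound 4 (0.42 log units; beyond the scatter).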

Compound 4, half-maximal inhibitory concentration: > 4000 nM
Compound 4 was reported as a limit; the forecaster's own chance of this, stated with the estimate: 15%; middle value at least 2.6-fold (0.42 log units) away from the limit.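

Compound 1 and compound 4 are both reported only as limits, so the step between them cannot be read: the limit of > 4000 nM in this assay, at which 2 of the 4 values shown sit.

Going by these compounds, whether 4-propylphenyl in place of 2-fluorophenyl on an amine nitrogen changes the number at all in this assay stays open.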